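The source may report more compounds than this note shows. Statements on the series, on what has been measured and on what is new or still open speak of the compounds shown alone.

Measured so far in an assay on isolated protein for displacement of a labelled ligand from Bcl-2-like protein 2 (Homo sapiens), read by fluorescence polarization; on this read-out higher numbers stand for weaker inhibition and lower numbers for stronger inhibition:
Compound 1 `C[C@@H](C(=O)O)N1C(=O)/C(=C/c2ccc(Br)cc2)SC1=S` gives 243000 nM.
Compound 2 `C=CCOC(=O)[C@H](C)N1C(=O)/C(=C/c2ccc(Br)cc2)SC1=S` gives only a limit of the assay, > 1000000 nM.

Compound 2 thus has no number of its own and stands at the weak end of what is shown, sitting on (the limit of > 1000000 nM in this assay, at which 1 of the 2 values shown sits). Going by the values given here, the only measured step is an at least 4.1-fold higher number from compound 1 to compound 2 (0.61 log units; beyond the scatter). Compound 3 `C[C@@H](C(=O)N1CCOCC1)N1C(=O)/C(=C/c2ccc(Br)cc2)SC1=S` differs from compound 2 by morpholin-4-yl in place of allyloxy on a carbonyl carbon. Among the compounds with values here, no measured step carries a change of this kind, so no step beyond the scatter is expected, and compound 3 is estimated to stay near the limit. Compound 3 is therefore expected at 900000 nM, between 300000 nM and 3000000 nM, an expected step of an at least 1.1-fold lower number from compound 2 to compound 3 (0.04 log units; that floor lies within the scatter) in this assay.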

Compound 3, inhibition constant: 146000 nM
Estimate against measurement, compound 3: 6.2-fold (0.79 log units) above; the measured number lies below the stated range.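

Morpholin-4-yl in place of allyloxy on a carbonyl carbon gives an at least 6.8-fold lower number from compound 2 to compound 3 (0.83 log units; beyond the scatter) in this assay, so a change at this position can also recover what the ester of compound 2 lost. Morpholin-4-yl in place of hydroxy gives a 1.7-fold lower number from compound 1 to compound 3 (0.22 log units; within the scatter), so the carboxylic acid of compound 1 can be replaced at this carbonyl carbon without a change beyond the scatter. Compound 2 remains a limit rather than a number: the limit of > 1000000 nM in this assay, at which 1 of the 3 values shown sits.

Going by these compounds, it remains open whether the ring oxygen of morpholin-4-yl matters, which a piperidin-1-yl group on the same carbon would test. A dimethylamino group there would test whether a ring is needed at all.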